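Isopropoxy to tert-butoxy: expected effect on atrial agonist activity

This account rests on a few compounds, and the source may have more. Where it says the series, first, only, none or still open, it means among the compounds named here.

Compound 1 `CC1=NC(C)=C([N+](=O)[O-])C(c2cccnc2)/C1=C(\O)OC(C)C` gives 28500 nM in a functional assay (cardiac atrium) for agonist activity, with Cavia porcellus as the target (on this read-out higher numbers stand for an effect only at larger amounts of compound and lower numbers for an effect already at smaller amounts), the highest of the three numbers here. Compound 2 `CCO/C(O)=C1\C(C)=NC(C)=C([N+](=O)[O-])C1c1ccccn1` gives 22800 nM, which lies within the scatter of compound 1. Compound 3 `CC1=NC(C)=C([N+](=O)[O-])C(c2ccncc2)/C1=C(\O)OCC(C)C` gives 8510 nM, a number that sits below compound 1 by more than the scatter. Compound 4 `CC1=NC(C)=C([N+](=O)[O-])C(c2cccnc2)/C1=C(\O)OC(C)(C)C` is not yet measured and differs from compound 1 by methyl in place of hydrogen on a saturated chain carbon bound to an oxygen on an unsaturated carbon and two saturated chain carbons. Within the data shown here, no pair of measured compounds isolates this change, since compounds 1, 2 and 3 differ at more than one place. Without an anchor for the step, only a small shift is expected, within the scatter: a 1.1-fold lower number from compound 1 to compound 4 (0.06 log units; within the scatter). For compound 4 the estimated value is 25000 nM, with a range from 8000 nM to 70000 nM.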

Compound 4, half-maximal effective concentration: 14600 nM
The estimate for compound 4 lay 1.7-fold (0.23 log units) above the measured number; low and high end bracket the measured number.
By their numbers in this assay, from the lowest: compounds 3, 4, 2 and 1 (each within the scatter of the next, the first and the last beyond it).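

In this assay, among these compounds, the isopropoxy to tert-butoxy change gives the first single-place step: a 2.0-fold lower number from compound 1 to compound 4 (0.29 log units; within the scatter). The added methyl on this saturated chain carbon therefore leaves the read-out within the scatter, and agonist activity remains measurable with tert-butoxy at this position. No available evidence bears on this step.

On these data alone, what a longer chain or an amine in place of this methyl would do remains open. As far as these compounds go, whether the same change gives a similar step on the cores of compound 2 or compound 3 is also open.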